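From 3-methoxyphenyl to 2,6-difluorophenyl on compound 2

A few compounds are considered here, and "the series" means these few. Any claim that something is new, unique, unknown or untested is made for them only; others in the source may bear on it.

Compound 1 `CCCOc1ccc(/C=C/C(=O)c2ccc(O)cc2)cc1`: 31100 nM
Compound 2 `COc1cccc(/C=C/C(=O)c2ccc(OCC(=O)Nc3ccc(OC)c(OC)c3)cc2)c1`: 33200 nM

In an ADME assay on MDCK-II cells (Canis lupus familiaris) for inhibition, read by MTT assay, with a stated time of 72 h (on this read-out higher numbers stand for weaker inhibition of growth and lower numbers for stronger inhibition of growth), compound 2 gives 33200 nM, and this lies within the usual scatter of compound 1 at 31100 nM, so the two cannot be ranked on this read-out. Within the data shown here, they do not form a pair that differs in one place, so no measured step shows what a single change does here.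

Compound 3 `COc1ccc(NC(=O)COc2ccc(C(=O)/C=C/c3c(F)cccc3F)cc2)cc1OC` has not yet been measured. It has 2,6-difluorophenyl in place of the 3-methoxyphenyl of compound 2, on a double-bonded chain carbon bound to a double-bonded chain carbon: 2,6-difluorophenyl in place of 3-methoxyphenyl on a double-bonded chain carbon bound to a double-bonded chain carbon. The rest of the structure stays the same.

Among the measured compounds shown here, with only two measured values to go on, and those two within the scatter of each other, no step beyond the scatter is expected in this assay, and neither direction is favoured. The estimated step is a 1.2-fold lower number from compound 2 to compound 3 (0.07 log units; within the scatter). For compound 3 the expected value is 28000 nM, with an estimated range from 10000 nM to 75000 nM.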

Compound 3, concentration for 50% growth inhibition: 36200 nM
Compound 3: the middle estimate sits 1.3-fold (0.11 log units) below what was measured; low and high end bracket the measured number.
By their numbers in this assay, from the lowest: compounds 1, 2 and 3 (each within the scatter of the next).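

Among these compounds, the exchange of 3-methoxyphenyl for 2,6-difluorophenyl on a double-bonded chain carbon bound to a double-bonded chain carbon gives the first single-place step in this set, a 1.1-fold higher number from compound 2 to compound 3 (0.04 log units; within the scatter) in this assay, so compound 2 and compound 3 cannot be told apart on this read-out. At this position, then, an aromatic ring of carbon only can lose its methoxy group and take on two fluorines, which also takes the count of hydrogen-bond acceptors in the group from one to none, without any step beyond the scatter appearing. No measurement is available to explain this result.

On these data alone, whether this position would respond to a group of another kind, such as an amine or a carboxylic acid in place of the aromatic ring, remains open, as the two groups compared here have the same count of heavy atoms and both carry a six-membered aromatic ring. Compound 1 differs from compound 2 and compound 3 in more than one place, so what the rest of the structure contributes in this assay also remains unsettled.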